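A methoxy group added to the anilino ring of compound 1

The compounds below may be only part of what the source reports. "The series", "measured", "known", "first", "only" and "open" are said of these compounds alone.

Measured so far:
Compound 1, `Cc1nc(SCC(=O)Nc2nc(-c3ccc(Cl)cc3)cs2)n(Nc2ccccc2)c1C`, in a functional assay on SN12C cells (Homo sapiens) for antiproliferative activity, read by sulforhodamine B assay, with a stated time of 48 h (on this read-out lower numbers stand for stronger inhibition of growth and higher numbers for weaker inhibition of growth), compound 1 gives 2380 nM.
Compound 2, `Cc1ccc(Nn2c(SCC(=O)Nc3nc(-c4ccccc4)cs3)nc(C)c2C)cc1`, in this assay compound 2 gives 3200 nM.

Of the compounds shown here, two have been measured. Compound 1 holds the lowest of the two numbers, yet its nearest neighbour, compound 2, lies within the usual scatter of the measurement, so the two cannot be told apart on the data at hand. Among the compounds with values here, compound 2 differs from compound 1 in more than one place, so no single step can be drawn between them; their two values simply show that both compounds sit in the same region.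

The unmeasured compound 3, `COc1ccc(Nn2c(SCC(=O)Nc3nc(-c4ccc(Cl)cc4)cs3)nc(C)c2C)cc1`, differs from compound 1 in one place: methoxy in place of hydrogen on an aromatic carbon. Nothing measured here describes this change on its own. Within the data shown here, the only comparison available, between compound 1 and compound 2, shows values within the scatter of each other, and that comparison involves other changes as well. The step of a 1.1-fold higher number from compound 1 to compound 3 (0.02 log units; within the scatter) is therefore expected to be small, with no clear direction beyond the scatter. For compound 3 the estimate in this assay is 2500 nM, with a range from 1000 nM to 6500 nM.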

Compound 3, concentration for 50% growth inhibition: 2300 nM
Estimate against measurement, compound 3: 1.1-fold (0.04 log units) above, within the range that was stated.
By their numbers in this assay, from the lowest: compounds 3, 1 and 2 (each within the scatter of the next).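

In this assay, within the data shown here, the change from anilino to (4-methoxyphenyl)amino is the first single change that can be read, and it comes out as a 1.0-fold lower number from compound 1 to compound 3 (0.01 log units; within the scatter) with nothing to separate the two compounds. This shows that this position, para to a large group, can carry a methoxy group, with its 2 heavy atoms and 1 hydrogen-bond acceptor, and the number stays within the scatter, something compound 2 could not show since it differs from compound 1 in more than one place. No measurement of any property accompanies this result, so the data offer no explanation for it.

What the compounds shown leave open is whether this tolerance extends to other groups at the same place, such as a hydroxyl, an amine or a carboxylic acid, or to a longer chain such as butoxy. They also leave open whether methoxy in place of hydrogen would read the same on other positions of that ring, where no group has yet been placed alone.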